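From fluoro to methoxy on a short-lived compound

A few compounds are considered here, and "the series" means these few. Any claim that something is new, unique, unknown or untested is made for them only; others in the source may bear on it.

Measured so far in an ADME assay on cells (Hepatocyte, Homo sapiens) for metabolic stability; on this read-out higher numbers stand for a longer-lived compound and lower numbers for a shorter-lived compound:
- Compound 1 (`O=c1cc(N2CCN(CC3CCC(NS(=O)(=O)c4ccccc4)CC3)CC2)sc2c([N+](=O)[O-])cc(C(F)(F)F)cc12`) gives > 1.55 h as a limit of the assay, not a number
- Compound 2 (`O=C(OC1CCC(CN2CCN(c3cc(=O)c4cc(C(F)(F)F)cc([N+](=O)[O-])c4s3)CC2)CC1)c1ccc(F)cc1`) gives 0.0983 h as a true number

Among the measured compounds shown here, compound 2 holds the only true number so far, so nothing can yet be ranked against it. Compound 3 (`COc1ccc(C(=O)OC2CCC(CN3CCN(c4cc(=O)c5cc(C(F)(F)F)cc([N+](=O)[O-])c5s4)CC3)CC2)cc1`) differs from compound 2 in one place (methoxy in place of fluoro on an aromatic carbon): methoxy in place of fluoro on an aromatic carbon, para to a large group.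

For the measured compounds named here, the only measured step is large (an at least 15-fold lower number from compound 1 to compound 2 (1.19 log units; beyond the scatter)) but it put ((4-fluorophenyl)carbonyl)oxy in place of (phenylsulfonyl)amino on a saturated ring carbon. Going by the values given here, no measured step touches the aromatic group alone. Compound 3 keeps the carbonyl-oxy link of compound 2 at 0.0983 h as its starting point, so a step of that size is not expected.

Expected in this assay is a 1.0-fold higher number from compound 2 to compound 3 (0.01 log units; within the scatter) with no step beyond the usual scatter and no favoured direction. Compound 3 is estimated at 0.1 h with a range from 0.04 h to 0.25 h as the expected spread.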

Compound 3, half-life: 0.165 h
Compound 3: middle estimate off by 1.7-fold (0.22 log units), on the low side; the measured number falls inside the stated range.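

In this assay, methoxy in place of fluoro on the aromatic carbon, para to a large group, gives a 1.7-fold higher number from compound 2 to compound 3 (0.22 log units; within the scatter), so this swap at this position produces no change that can be told from the scatter. With the methoxy group in place, the ((4-methoxyphenyl)carbonyl)oxy group on the saturated ring carbon still leaves an at least 9.3-fold lower number from compound 1 to compound 3 (0.97 log units; beyond the scatter), so the gap that first appeared with the fluoro version does not close with this swap. That gap has only a minimum size, since compound 1 carries a limit of the assay and not a true number: the limit of > 1.55 h in this assay, at which 1 of the 3 values shown sits.

Going by these compounds, whether an amine or a carboxylic acid at this aromatic position would move the half-life beyond the scatter remains open. Also open, on these data alone, is whether a methoxy group on the phenyl ring of the (phenylsulfonyl)amino series would behave as it does here.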